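A few compounds are considered here, and "the series" means these few. Any claim that something is new, unique, unknown or untested is made for them only; others in the source may bear on it.

Compound 2 `Cc1ccc(-n2nncc2CN2C(=O)C3(C(C#N)=C(N)Oc4c(N)cc5nc6ccccc6nc5c43)c3ccccc32)cc1C` stands at a limit in an ADME assay on L02 cells (Homo sapiens) for antiproliferative activity, read by MTT assay, with a stated time of 48 h; a lower number here means a stronger inhibitor, a higher number a weaker inhibitor: compound 2 gives > 50000 nM, which is a limit of the assay and not a number. Its one comparator, compound 1 `N#CC1=C(N)Oc2c(N)cc3nc4ccccc4nc3c2C12C(=O)N(Cc1cnnn1-c1ccc(Cl)cc1)c1ccccc12`, gives in this assay > 50000 nM, again a limit of the assay. Within the data shown here, the only measured step, a step that the two limits leave unreadable from compound 1 to compound 2, therefore cannot be read in size or direction; what the pair shows is simply (the limit of > 50000 nM in this assay, at which 2 of the 2 values shown sit). Compound 3 `N#CC1=C(N)Oc2c(N)cc3nc4ccccc4nc3c2C12C(=O)N(Cc1cnnn1-c1c(F)cccc1F)c1ccccc12` differs from compound 2 by 2,6-difluorophenyl in place of 3,4-dimethylphenyl on an aromatic nitrogen. Among the measured compounds shown here, this change touches the same aryl group on the aromatic nitrogen that the measured step changed, but since that step is unreadable, the data give no size for a step in this assay in either direction, and nothing suggests a move beyond the scatter. The expectation for compound 3 is therefore that it too sits at the limit, with a step that the limit leaves unreadable from compound 2 to compound 3 expected to be no step beyond the scatter. Compound 3 is estimated at 60000 nM, within a range from 25000 nM to 150000 nM, with the likely outcome that the assay reports only a limit once more.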

Compound 3, half-maximal inhibitory concentration: > 50000 nM
Compound 3 was reported as a limit (the forecaster's own chance of this, stated with the estimate: 80%); the middle value does not contradict the limit.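

No step among compound 1, compound 2 and compound 3 can be read in size or direction, because all three give only a limit of the assay and not a number: the limit of > 50000 nM in this assay, at which 3 of the 3 values shown sit.

From the compounds shown here alone, whether the 4-chlorophenyl, 3,4-dimethylphenyl and 2,6-difluorophenyl groups differ at all in this assay stays open.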